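Sulfonyl aryl swap in the diarylaminopyrimidine sulfonamide series

The compounds below may be only part of what the source reports. "The series", "measured", "known", "first", "only" and "open" are said of these compounds alone.

Compound 2 `COc1ccc(Nc2cc(C)nc(Nc3ccc(NS(=O)(=O)c4ccccc4Cl)cc3)n2)cc1` is measured in a functional assay on MDA-MB-468 cells (Homo sapiens) for antiproliferative activity, read by MTT assay (on this read-out higher numbers stand for weaker inhibition and lower numbers for stronger inhibition), where it reaches only the limit of > 50000 nM. Compound 1 `COc1cc(C)cc(Cl)c1S(=O)(=O)Nc1ccc(Nc2nc(C)cc(Nc3ccc(F)cc3)n2)cc1` likewise gives only the limit of > 50000 nM. Both values therefore sit at the limit of > 50000 nM in this assay, at which 2 of the 2 values shown sit. Compound 3 `COc1ccc(Nc2cc(C)nc(Nc3ccc(NS(=O)(=O)c4c(Cl)cc(C)cc4OC)cc3)n2)cc1` is not yet measured; it carries 2-chloro-6-methoxy-4-methylphenyl in place of 2-chlorophenyl on a sulfonyl sulfur, the same sulfonyl aryl group that compound 1 bears. The step from compound 2 to compound 3 is expected to be none beyond the scatter, given a step that the limit leaves unreadable from compound 2 to compound 3, with compound 3 most likely again reported as a limit. Compound 3 is estimated at 60000 nM, within 20000 nM to 200000 nM.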

Compound 3, half-maximal inhibitory concentration: > 50000 nM
Compound 3: no number, only a limit (the forecaster's own chance of this, stated with the estimate: 85%); the middle value lies beyond the limit too.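

Among the compounds shown here, compound 1, compound 2 and compound 3 all give only limits in this assay, so no step among them can be read: the limit of > 50000 nM in this assay, at which 3 of the 3 values shown sit. The compounds shown leave open whether either swap, 2-chloro-6-methoxy-4-methylphenyl for 2-chlorophenyl or methoxy for fluoro, changes inhibition at all.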